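A few compounds are considered here, and "the series" means these few. Any claim that something is new, unique, unknown or untested is made for them only; others in the source may bear on it.

For the measured compounds named here, in an ADME assay on HEL cells (Homo sapiens) for cytotoxicity, with a stated time of 3 days (on this read-out lower numbers stand for higher toxicity in this test and higher numbers for lower toxicity in this test), compound 1, `Cc1cc(-c2cccc(O)c2)c2ncc(CSCCc3ccccc3)n2c1`, gives 11.4 ug/mL, and this is the only exact number so far. The other tested compound, compound 2, `Cc1cc(I)cn2c(CSCCc3ccccc3)cnc12`, is recorded at > 50 ug/mL, which is a limit of the assay and not a number. Going by the values given here, compound 1 therefore has no second exact value to be ranked against, and no measured step between two close relatives is available as a guide.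

The next compound is compound 3, `COc1ccc(-c2cc(C)cn3c(CSCCc4ccccc4)cnc23)cc1`. It keeps the core of compound 1 and changes one group: 4-methoxyphenyl in place of 3-hydroxyphenyl on an aromatic carbon. In words, 4-methoxyphenyl stands in place of 3-hydroxyphenyl on an aromatic carbon, so an aromatic ring of carbon remains at that place while the hydrogen-bond donor is gone.

Among the compounds with values here, with no measured step to lean on, no change beyond the usual scatter is expected in this assay, although this expectation is loose. The expected step, a 1.2-fold higher number from compound 1 to compound 3 (0.09 log units; within the scatter), is only an estimate. For compound 3 the estimated value is 14 ug/mL, with an expected range from 5 ug/mL to 40 ug/mL.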

Compound 3, half-maximal cytotoxic concentration: 19.6 ug/mL
Compound 3: middle estimate off by 1.4-fold (0.15 log units), on the low side; low and high end bracket the measured number.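

Putting 4-methoxyphenyl in place of 3-hydroxyphenyl on this aromatic carbon gives a 1.7-fold higher number from compound 1 to compound 3 (0.24 log units; within the scatter), so in this assay the two compounds cannot be told apart. For the compounds shown here, this is the first measured step at this position, and it shows that the aromatic ring here can go from carrying 1 hydrogen-bond donor to carrying none while the two numbers stay within the usual scatter of each other. Compound 2, which carries iodine at the same place, adds no exact number for comparison, as its entry is a limit of the assay and not a number: the limit of > 50 ug/mL in this assay, at which 1 of the 3 values shown sits.

The step changes two things at once, where the oxygen sits on the ring and whether it carries a hydrogen or a methyl group, so the two pairs shown cannot separate these effects, and 3-methoxyphenyl or 4-hydroxyphenyl would be needed to do so. From the compounds shown here alone, it also remains open whether a phenyl ring bearing an amine or a carboxylic acid would stay within the scatter of these two compounds or move beyond it.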